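Working notes: cyano in place of nitro

The source may hold more compounds than are shown below. What is called first, only, known or untested is meant among the compounds shown, and "the series" means these compounds.

Compound 1 `O=S(=O)(Nc1ccc(Cl)c2cc[nH]c12)c1ccc(Cl)cc1`: 0.66 ug/mL
Compound 2 `O=[N+]([O-])c1ccc(S(=O)(=O)Nc2ccc(Cl)c3cc[nH]c23)cc1`: 0.67 ug/mL

In a functional assay on MC-38 cells (Mus musculus) for antiproliferative activity, read by colorimetric assay and MTT assay (a lower number here means a stronger inhibitor, a higher number a weaker inhibitor), compound 2 gives 0.67 ug/mL, level with compound 1 within the scatter. Compound 3 `N#Cc1ccc(S(=O)(=O)Nc2ccc(Cl)c3cc[nH]c23)cc1` has cyano in place of nitro on an aromatic carbon, para to a large group: cyano in place of nitro on an aromatic carbon. Among the measured compounds shown here, one measured step bears on this place: a 1.0-fold higher number from compound 1 to compound 2 (0.01 log units; within the scatter), with nitro in place of chloro. With that step inside the scatter, no step beyond the scatter is expected in this assay. The expected step is a 1.0-fold higher number from compound 2 to compound 3 (0.02 log units; within the scatter). For compound 3 the estimated value is 0.7 ug/mL, with an expected range of 0.35 ug/mL to 1.4 ug/mL.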

Compound 3, half-maximal inhibitory concentration: 0.22 ug/mL
Compound 3: middle estimate off by 3.2-fold (0.50 log units), on the high side; the whole stated range lies above it.
By their numbers in this assay, from the lowest: compound 3; then compounds 1 and 2 (each within the scatter of the next).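

At this place, on an aromatic carbon para to a large group, the substituent does matter in this assay: chloro and nitro stayed level within the scatter, whereas a 3.0-fold lower number from compound 2 to compound 3 (0.48 log units; beyond the scatter) and a 3.0-fold lower number from compound 1 to compound 3 (0.48 log units; beyond the scatter) come with cyano. Among these three groups, cyano alone stands apart. Nothing measured here accounts for this step.

On these data alone, whether an amine, a carboxylic acid or a methoxy group at this place would match cyano or stay level with chloro and nitro remains open. As far as these compounds go, whether the step carries over to other cell lines is also open.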